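Swapping sulfur for selenium on a shared core

The source may hold more compounds than are shown below. What is called first, only, known or untested is meant among the compounds shown, and "the series" means these compounds.

Compound 1, `CS/C(=N\C(=O)c1csc([N+](=O)[O-])c1)NC(=O)c1csc([N+](=O)[O-])c1`, gives 21400 nM in an ADME assay on MCF-10A cells (Homo sapiens) for cytotoxicity, read by MTT assay, with a stated time of 72 h; a higher number here means a weaker inhibitor of growth, a lower number a stronger inhibitor of growth.
Compound 2, `CS/C(=N\C(=O)c1ccco1)NC(=O)c1ccco1`, gives 46500 nM in this assay.
Compound 3, `O=C(/N=C(/NC(=O)c1ccno1)[Se]Cc1ccccc1)c1ccno1`, gives only > 100000 nM in this assay, which is a limit of the assay and not a number.

Among the two numbers in hand, compound 1 holds the lowest, meaning it is the stronger inhibitor of growth of the pair. The nearest, compound 2, sits higher by a gap that is beyond the usual scatter of repeated measurements. For compound 3 the assay reports (the limit of > 100000 nM in this assay, at which 1 of the 3 values shown sits), so no number can be set beside the others.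

Compound 4, `C[Se]/C(=N\C(=O)c1csc([N+](=O)[O-])c1)NC(=O)c1csc([N+](=O)[O-])c1`, shares the core of compound 1 and differs from it by a group of 2 heavy atoms (1 carbon, 1 selenium; no ring) in place of a group of 2 heavy atoms (1 carbon, 1 sulfur; no ring), on a carbon with a double bond to nitrogen. Going by the values given here, no two measured compounds differ by exactly this swap, so there is no measured step to lean on, and the expectation rests on compound 1 alone. The change is expected to move the number little, by a step from compound 1 to compound 4 of about a 1.2-fold lower number from compound 1 to compound 4 (0.08 log units; within the scatter), which is within the scatter. Compound 4 is therefore expected to give 18000 nM, with a likely range from 7000 nM to 50000 nM.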

Compound 4, concentration for total growth inhibition: 4740 nM
Compound 4: the middle estimate sits 3.8-fold (0.58 log units) above what was measured, and the stated range ends above it.
By their numbers in this assay, from the lowest: compound 4; then compound 1; then compound 2. At a limit, above all of these: compound 3.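

In this assay, putting selenium in place of the sulfur of the methylsulfanyl group gives a 4.5-fold lower number from compound 1 to compound 4 (0.65 log units; beyond the scatter), so the stronger inhibitor of growth of this pair is the selenium compound. This pair is the first shown that differs in one place, and it shows that the group on a carbon with a double bond to nitrogen is not a silent spot: exchanging sulfur for selenium alone, with the rest of the core of compound 1 unchanged, is enough to shift the number. Nothing measured here says why the swap has this effect, since the only supporting data concern an assay limit and do not bear on the step.

The compounds shown leave open whether the same swap would move the number in the same direction on compound 2, since this single pair cannot show a general rule. They also leave open how the position would respond to a longer chain on the selenium, such as an ethyl group, or to an amine in place of the whole group.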